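This account rests on a few compounds, and the source may have more. Where it says the series, first, only, none or still open, it means among the compounds named here.

Compound 1 `OC[C@H]1O[C@@H](n2cnc3c(NCc4cccc(F)c4)ncnc32)[C@H](O)[C@@H]1O`, compound 2 `OC[C@H]1O[C@@H](n2cnc3c(NCc4ccccc4Br)ncnc32)[C@H](O)[C@@H]1O` and compound 3 `COc1cc(CNc2ncnc3c2ncn3[C@@H]2O[C@H](CO)[C@@H](O)[C@H]2O)cc(OC)c1` share one core and differ only in the group carried on the saturated chain carbon bound to a nitrogen on an aromatic ring. In a functional assay on B16 cells (Mus musculus) for antiproliferative activity, with a stated time of 72 h (a higher number here means a weaker inhibitor, a lower number a stronger inhibitor), compound 1 gives "not determined" (no result reported). In this assay compound 3 likewise gives "not determined" (no result reported). Compound 2 is the only one of the three with a recorded result, and that result is a limit of the assay rather than a number: in this assay compound 2 gives > 166000 nM. Compound 2 therefore stands at the limit of > 166000 nM in this assay, at which 1 of the 3 values shown sits.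

Compound 4 `OC[C@H]1O[C@@H](n2cnc3c(NCc4c(F)ccc(F)c4F)ncnc32)[C@H](O)[C@@H]1O` is not yet measured. It differs from compound 2 in one place: 2,3,6-trifluorophenyl in place of 2-bromophenyl on a saturated chain carbon bound to a nitrogen on an aromatic ring.

Among the compounds with values here, with no measured step between any two compounds, the size of the change from compound 2 to compound 4 in this assay cannot be read from the data, and no shift beyond the usual scatter is expected; the estimated step is an at least 1.0-fold lower number from compound 2 to compound 4 (0.01 log units; that floor lies within the scatter). For compound 4 the expected result in this assay is 160000 nM, within a range of 50000 nM to 500000 nM, most likely reported again only as a limit.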

Compound 4, half-maximal inhibitory concentration: > 166000 nM
Compound 4: a limit, no number; the forecaster's own chance of this, stated with the estimate: 70%; middle value at least 1.0-fold (0.01 log units) away from the limit.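

Compound 2 and compound 4 both rest at a limit of this assay rather than at a number, so no step between them can be read: the limit of > 166000 nM in this assay, at which 2 of the 4 values shown sit.

The compounds shown leave open whether any group on this saturated chain carbon yields an actual number in this assay.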